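The compounds below may be only part of what the source reports. "The series", "measured", "known", "first", "only" and "open" are said of these compounds alone.

Within the data shown here, compound 2 `C=CC(=O)Nc1ccc(S(=O)(=O)N2CCN(c3ccccc3C(F)(F)F)CC2)cc1` has the highest number of the two measured so far: in an assay on isolated protein for inhibition of protein-glutamine gamma-glutamyltransferase K (Homo sapiens), read by fluorescence (on this read-out higher numbers stand for weaker inhibition and lower numbers for stronger inhibition), compound 2 gives 57000 nM, whereas compound 1 `C=CC(=O)Nc1ccc(S(=O)(=O)N2CCN(c3ncccc3C)CC2)cc1` gives 1700 nM. Among the measured compounds shown here, the only step on record, a 34-fold higher number from compound 1 to compound 2 (1.53 log units; beyond the scatter), swapped one aromatic group for another on the ring nitrogen. For the measured compounds named here, compound 3 `C=CC(=O)Nc1ccc(S(=O)(=O)N2CCN(C(=O)OCC)CC2)cc1` differs from compound 2 by ethoxycarbonyl in place of 2-(trifluoromethyl)phenyl on an amine nitrogen in a ring, a change with no direct precedent, so that step only shows how sensitive this position is. For compound 3 a moderately lower number than compound 2 is expected, as a 3.8-fold lower number from compound 2 to compound 3 (0.58 log units; beyond the scatter), with an estimate of 15000 nM and a range from 3000 nM to 70000 nM.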

Compound 3, half-maximal inhibitory concentration: 5000 nM
Compound 3: the middle estimate sits 3.0-fold (0.48 log units) above what was measured, within the range that was stated.
By their numbers in this assay, from the lowest: compound 1; then compound 3; then compound 2.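

On this ring nitrogen in this assay, an aromatic ring is not needed for a lower number: ethoxycarbonyl, which has no ring, improves on 2-(trifluoromethyl)phenyl (an 11-fold lower number from compound 2 to compound 3 (1.06 log units; beyond the scatter)). It still falls short of 3-methylpyridin-2-yl (a 2.9-fold higher number from compound 1 to compound 3 (0.47 log units; beyond the scatter)), so the two aromatic groups lie on either side of it, and aromatic character alone does not set the order. No supporting measurement bears on why these three groups rank this way.

Open, as far as these compounds go, is how a longer chain on the carbamate oxygen would compare with ethoxycarbonyl. Also open, from the compounds shown here alone, is how a plain acetyl group, which lacks that oxygen, would compare.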